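Methyl-to-phenyl swap on the five-membered ring of compound 1

The compounds below may be only part of what the source reports. "The series", "measured", "known", "first", "only" and "open" are said of these compounds alone.

Measured so far in a functional assay on MIA PaCa-2 cells (Homo sapiens) for antiproliferative activity, read by WST assay, with a stated time of 72 h; a higher number here means a weaker inhibitor, a lower number a stronger inhibitor:
compound 1 `COc1ccc2[nH]c(-c3nc(C)no3)cc2c1` gives > 50000 nM, a limit of the assay.
compound 2 `Cc1noc(-c2cc3cc(Cl)ccc3[nH]2)n1` gives > 50000 nM, likewise a limit of the assay.

Compound 1 stands only at a limit; no number is known for it. The step from compound 1 to compound 2, chloro in place of methoxy on an aromatic carbon, is a step that the two limits leave unreadable from compound 1 to compound 2, so it tells nothing about size or direction. Among the measured compounds shown here, the only evidence on the measured pair is the limit of > 50000 nM in this assay, at which 2 of the 2 values shown sit.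

Compound 3 `COc1ccc2[nH]c(-c3nc(-c4ccccc4)no3)cc2c1` differs from compound 1 by phenyl in place of methyl on an aromatic carbon. No measured step touches this position on the five-membered aromatic ring with 2 nitrogen and 1 oxygen, so nothing shown bears on it. With compound 1 at > 50000 nM as a limit, the expectation for compound 3 rests on that limit alone. Compound 3 is estimated at 40000 nM, with a range from 8000 nM to 200000 nM; the expected step from compound 1 to compound 3 is an at least 1.2-fold lower number from compound 1 to compound 3 (0.09 log units; that floor lies within the scatter), and a further limit rather than a number is the more likely outcome.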

Compound 3, half-maximal inhibitory concentration: 32600 nM
Compound 3: middle estimate off by 1.2-fold (0.09 log units), on the high side; measured number inside the range.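

In this assay, among the compounds shown here, compound 3 gives 32600 nM, the first value that is a number and not a limit, so this aromatic carbon between two ring nitrogen atoms can carry phenyl with a readable result. Phenyl in place of methyl gives an at least 1.5-fold lower number from compound 1 to compound 3 (0.18 log units; that floor lies within the scatter) and sets no upper bound on the size of the change. Only a floor can be read, and the true size of the step stays unknown, the starting point being a limit rather than a number: the limit of > 50000 nM in this assay, at which 2 of the 3 values shown sit.

Open, going by these compounds, is whether an amine, a carboxylic acid or a longer alkyl chain at this carbon would give a lower number than phenyl does. Also open, on these data alone, is whether phenyl at this carbon would give a readable value with chloro in place of methoxy on the shared core.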